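A Fluorine-for-Bromine Swap Across Two Cores

This account rests on a few compounds, and the source may have more. Where it says the series, first, only, none or still open, it means among the compounds named here.

Compound 1 `COc1ccc2nc(N(Cc3cc(-c4ccc(Br)cc4)no3)c3nc4ccc(F)cc4s3)sc2c1` gives 41200 nM in a functional assay on MCF7 cells (Homo sapiens) for antiproliferative activity, read by MTT assay; a higher number here means a weaker inhibitor, a lower number a stronger inhibitor. Compound 2 `COc1ccc2nc(N(Cc3cc(-c4ccccc4F)no3)c3nc4ccc(F)cc4s3)sc2c1` gives 28500 nM in this assay. The change between them is 2-fluorophenyl in place of 4-bromophenyl on an aromatic carbon and made a 1.4-fold lower number from compound 1 to compound 2 (0.16 log units; within the scatter). Compound 3 `Brc1ccc(-c2cc(CN(c3ncccn3)c3nc4ccccc4s3)on2)cc1` gives 21100 nM in this assay; how its core differs from the core of compound 1 is not broken down here. For the measured compounds named here, compound 4 `Fc1ccccc1-c1cc(CN(c2ncccn2)c2nc3ccccc3s2)on1` is not yet measured; it differs from compound 3 by 2-fluorophenyl in place of 4-bromophenyl on an aromatic carbon, the same change as the one from compound 1 to compound 2, at a place described in the same words. Because a 1.4-fold lower number from compound 1 to compound 2 (0.16 log units; within the scatter) stayed within the scatter, compound 4 is expected to sit close to compound 3, with an estimated step of a 1.3-fold lower number from compound 3 to compound 4 (0.12 log units; within the scatter). Compound 4 is expected to give about 16000 nM in this assay, between 7000 nM and 40000 nM.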

Compound 4, half-maximal inhibitory concentration: 19500 nM
For compound 4 the middle estimate is 1.2-fold (0.09 log units) below the measured one; low and high end bracket the measured number.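

In this assay the swap to 2-fluorophenyl in place of 4-bromophenyl on the core of compound 3 gave a 1.1-fold lower number from compound 3 to compound 4 (0.03 log units; within the scatter). Set beside the earlier step, the change shows no detectable dependence on which of the two cores carries it: the same change on two cores in this assay, a 1.4-fold lower number (0.16 log units; within the scatter) from compound 1 to compound 2 and a 1.1-fold lower number (0.03 log units; within the scatter) from compound 3 to compound 4, 1.3-fold (0.13 log units) apart, within the scatter of two such steps. For the compounds shown here, this shows only that the change stayed within the scatter on both cores; it does not show that either group is the better one on either core, nor how the change would behave on any further core.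

Only 4-bromophenyl and 2-fluorophenyl appear at this place on the five-membered ring. As far as these compounds go, what an amine, a carboxylic acid or a longer chain would give there remains open.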